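Cytotoxicity notes: ethoxycarbonyl on the aromatic nitrogen

The source may hold more compounds than are shown below. What is called first, only, known or untested is meant among the compounds shown, and "the series" means these compounds.

- compound 1 `COC(=O)Cn1c2ccc([N+](=O)[O-])cc2c(=O)n1Cc1ccccc1`: 129000 nM
- compound 2 `CNC(=O)CCCn1c2ccc([N+](=O)[O-])cc2c(=O)n1Cc1ccccc1`: > 256000 nM

In an ADME assay on L929 cells (Mus musculus) for cytotoxicity, read by resazurin assay, with a stated time of 48 h (a lower number here means that less compound is tolerated, a higher number that more compound is tolerated), compound 2 stands at > 256000 nM, which is a limit and not a number. Compound 3 `CCOC(=O)n1c2ccc([N+](=O)[O-])cc2c(=O)n1Cc1ccccc1` differs from it as follows: ethoxycarbonyl in place of 3-(methylcarbamoyl)propyl on an aromatic nitrogen. Within the data shown here, one measured step bears on this change: an at least 1.9-fold higher number from compound 1 to compound 2 (0.29 log units; that floor lies within the scatter). That step replaces methoxycarbonyl on a chain carbon with 2-(methylcarbamoyl)ethyl, so compound 3, with ethoxycarbonyl, is expected to lie nearer compound 1 at 129000 nM. The expected change is an at least 2.3-fold lower number from compound 2 to compound 3 (0.36 log units; beyond the scatter) in this assay, towards a lower number. Compound 3 is estimated at 110000 nM, with an expected range of 40000 nM to 256000 nM.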

Compound 3, concentration lethal to 50% of the cells: 122000 nM
Beside the measured number, compound 3's estimate is 1.1-fold (0.04 log units) below it; measured number inside the range.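

In this assay, ethoxycarbonyl in place of 3-(methylcarbamoyl)propyl on the aromatic nitrogen gives an at least 2.0-fold lower number from compound 2 to compound 3 (0.32 log units; beyond the scatter). Compound 2 stands at > 256000 nM, which is a limit and not a number, so that step is only a floor. Ethoxycarbonyl and (methoxycarbonyl)methyl on this nitrogen cannot be told apart, with a 1.1-fold lower number from compound 1 to compound 3 (0.02 log units; within the scatter).

As far as these compounds go, how far compound 2 lies past its limit stays open, as does whether the chain length or the methylcarbamoyl end accounts for the step. From the compounds shown here alone, what a carboxylic acid or an amine at the end of a chain on this nitrogen would give also remains open.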